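The source may hold more compounds than are shown below. What is called first, only, known or untested is meant among the compounds shown, and "the series" means these compounds.

Compound 1 `O=S(=O)(Nc1ccc(F)c(Cl)c1)c1ccc(-c2cnc(C3CC3)o2)cc1` gives 73700 nM in a functional assay on cells (leukaemia cell line, Homo sapiens) for inhibition, read by sulforhodamine B assay, with a stated time of 48 h; a lower number here means a stronger inhibitor of growth, a higher number a weaker inhibitor of growth.
Compound 2 `Cc1ccc(NS(=O)(=O)c2ccc(-c3cnc(C4CC4)o3)cc2)cc1C` reaches only the limit > 100000 nM in this assay, which is a limit of the measurement and not a number.

Going by the values given here, compound 1 is the only compound with a finished number in this assay; the second value shown is a limit, as the limit of > 100000 nM in this assay, at which 1 of the 2 values shown sits, records, so compound 1 stands alone as the reference point and is itself a weak inhibitor of growth.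

Compound 3 `Cc1cc(Cl)ccc1NS(=O)(=O)c1ccc(-c2cnc(C3CC3)o2)cc1` has not been measured in this assay. It differs from compound 1 in one place: 4-chloro-2-methylphenyl in place of 3-chloro-4-fluorophenyl on a sulfonamide nitrogen.

Among the compounds with values here, only one measured step bears on this change, the exchange of the aryl group on the sulfonamide nitrogen, and it gives an at least 1.3-fold higher number from compound 1 to compound 2 (0.13 log units; that floor lies within the scatter). That step was also an exchange of one substituted phenyl for another at the same position and produced no change that rises above the scatter; the second compound merely ran into the limit of the measurement. For compound 3 a similar outcome is therefore expected: a number close to that of compound 1, with a real chance that only the limit is reported. The estimate for compound 3 in this assay is 85000 nM, within 30000 nM to 250000 nM, which means an expected step of a 1.2-fold higher number from compound 1 to compound 3 (0.06 log units; within the scatter).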

Compound 3, concentration for total growth inhibition: 54700 nM
Compound 3: middle estimate off by 1.6-fold (0.19 log units), on the high side; the measured number falls inside the stated range.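

In this assay, the position on the sulfonamide nitrogen now has two aryl groups with finished numbers, and the exchange of 3-chloro-4-fluorophenyl for 4-chloro-2-methylphenyl gives a 1.3-fold lower number from compound 1 to compound 3 (0.13 log units; within the scatter), so compound 1 and compound 3 cannot be told apart. This shows that a methyl group and a chlorine in the positions of 4-chloro-2-methylphenyl are tolerated as well as the halogens of 3-chloro-4-fluorophenyl, with no gain that rises above the scatter. The exchange of 3,4-dimethylphenyl for 4-chloro-2-methylphenyl gives an at least 1.8-fold lower number from compound 2 to compound 3 (0.26 log units; that floor lies within the scatter), and this can be read only as a floor, because compound 2 stands at a limit of the measurement and not at a number: the limit of > 100000 nM in this assay, at which 1 of the 3 values shown sits.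

The compounds shown all carry a substituted phenyl at this position, so they leave open whether an amine or a carboxylic acid on that phenyl, or a longer chain in its place, would move the number beyond the scatter. On these data alone, the shared core is the same in all of them, and what a change elsewhere in it would do remains open.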